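This account rests on a few compounds, and the source may have more. Where it says the series, first, only, none or still open, it means among the compounds named here.

Compound 2 `O=C(/C(=C\c1ccc(Br)c([N+](=O)[O-])c1)S(=O)(=O)c1ccc(Br)cc1)c1ccc(Br)cc1` stands in a functional assay on DU-145 cells (Homo sapiens) for inhibition, read by trypan blue exclusion, with a stated time of 96 h (a lower number here means a stronger inhibitor of growth, a higher number a weaker inhibitor of growth), at 10000 nM, level with compound 1 `O=C(/C(=C\c1ccc(Cl)c([N+](=O)[O-])c1)S(=O)(=O)c1ccc(Br)cc1)c1ccc(Br)cc1`, which gives 10000 nM. The change of bromo in place of chloro on an aromatic carbon left the read-out flat, no change at the digits printed from compound 1 to compound 2 (within the scatter), within the scatter. Compound 3 `O=C(/C(=C\c1ccc(F)c([N+](=O)[O-])c1)S(=O)(=O)c1ccc(Br)cc1)c1ccc(Br)cc1` differs from compound 2 by fluoro in place of bromo on an aromatic carbon. Among the compounds with values here, the one step on record at that aromatic carbon was flat, so this further exchange is expected to move this assay by nothing beyond the scatter. Compound 3 is therefore estimated at 10000 nM, between 3000 nM and 30000 nM. The expected step is no change at the digits printed from compound 2 to compound 3 (within the scatter).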

Compound 3, concentration for 50% growth inhibition: 25000 nM
Compound 3: the middle estimate sits 2.5-fold (0.40 log units) below what was measured, and the stated range covers the measured number.
By their numbers in this assay, from the lowest: compounds 1 and 2 (each within the scatter of the next); then compound 3.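

In this assay this aromatic carbon proves not to be indifferent to its halogen: fluoro in place of bromo gives a 2.5-fold higher number from compound 2 to compound 3 (0.40 log units; beyond the scatter) and fluoro in place of chloro gives a 2.5-fold higher number from compound 1 to compound 3 (0.40 log units; beyond the scatter) even though chloro and bromo had stood level. Among the three halogens shown, fluoro alone stands apart, and the move it brings is modest. No evidence at hand bears on why this is so.

The compounds shown leave open whether a group other than a halogen at this carbon, such as an amine, a methoxy group or a nitrile, would give a lower number. They also leave open whether the 4-fluoro-3-nitrophenyl result would hold on a core with other groups in place of the two bromo substituents.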